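From a Urea to a Benzamide: Expecting Compound 4

This account rests on a few compounds, and the source may have more. Where it says the series, first, only, none or still open, it means among the compounds named here.

Compound 1 `O=C(Nc1cccc(-n2cc(-c3ccncc3)c(-c3ccc(Cl)c(O)c3)n2)c1)Nc1cccc(C(F)(F)F)c1` gives 4260 nM in a functional assay on SF-295 cells (Homo sapiens) for inhibition, read by sulforhodamine B assay, with a stated time of 48 h; a higher number here means a weaker inhibitor of growth, a lower number a stronger inhibitor of growth. Compound 2 `COc1cc(-c2nn(-c3cccc(NC(=O)Nc4cc(C(F)(F)F)cc(C(F)(F)F)c4)c3)cc2-c2ccncc2)ccc1Cl` gives 1230 nM. Compound 3 `COc1cc(-c2nn(-c3cccc(NC(=O)Nc4cccc(C(F)(F)F)c4)c3)cc2-c2ccncc2)ccc1Cl` gives 1130 nM.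

Compound 3 stands at the lowest of the three numbers, though compound 2 lies within the scatter of it; only compound 1 sits clearly higher, as a 3.8-fold lower number from compound 1 to compound 3 (0.58 log units; beyond the scatter) shows. Compound 4 `COc1cc(-c2nn(-c3cccc(NC(=O)c4ccccc4)c3)cc2-c2ccncc2)ccc1Cl` differs from compound 3 by phenyl in place of (3-(trifluoromethyl)phenyl)amino on a carbonyl carbon. Neither measured step bears directly on this change: a 3.8-fold lower number from compound 1 to compound 3 (0.58 log units; beyond the scatter) concerns the oxygen substituent, and a 1.1-fold lower number from compound 2 to compound 3 (0.04 log units; within the scatter) concerns only a trifluoromethyl count while the urea is kept. The change to compound 4 removes the urea itself, for which no comparison exists, so a step beyond the scatter toward a higher number is expected, a 3.1-fold higher number from compound 3 to compound 4 (0.49 log units; beyond the scatter). Compound 4 is estimated at 3500 nM, within 900 nM to 14000 nM.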

Compound 4, concentration for total growth inhibition: 2260 nM
Compound 4: middle estimate off by 1.5-fold (0.19 log units), on the high side; measured number inside the range.
By their numbers in this assay, from the lowest: compounds 3, 2, 4 and 1 (each within the scatter of the next, the first and the last beyond it).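

Exchanging (3-(trifluoromethyl)phenyl)amino for phenyl on the carbonyl carbon gives a 2.0-fold higher number from compound 3 to compound 4 (0.30 log units; within the scatter) in this assay, the first change shown at this position. The urea is therefore not shown to be required here, since a benzamide with neither the trifluoromethyl nor the urea hydrogen stays within the scatter of compound 3. No measured evidence accounts for this result.

From the compounds shown here alone, this single step removes both features at once, so their separate contributions remain open. Also open, going by these compounds, is how a morpholine or a carboxylic acid on the phenyl of compound 4 would read.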